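A few compounds are considered here, and "the series" means these few. Any claim that something is new, unique, unknown or untested is made for them only; others in the source may bear on it.

Three compounds have already been run through an ADME assay on DU-145 cells (Homo sapiens) for cytotoxicity, read by MTT assay, with a stated time of 72 h (a higher number here means a weaker inhibitor, a lower number a stronger inhibitor), and a fourth waits its turn. Compound 1 `COc1ccc(C2=C(c3cc(OC)c(OC)c(OC)c3)C(=O)C(OC(C)=O)C2)cc1` carries an acetoxy group on the saturated ring of its core, while compound 2 `COc1ccc(C2=C(c3cc(OC)c(OC)c(OC)c3)C(=O)C(O)C2)cc1` carries a hydroxy group there instead. Compound 3 `COc1cc(C2=C(c3cc(C)c(OC)c(C)c3)C(O)CC2=O)cc(OC)c1OC` is built on another core, and compound 4 `COc1cc(C2=C(c3cc(C)c(OC)c(C)c3)C(OC(C)=O)CC2=O)cc(OC)c1OC` is compound 3 with the hydroxy group turned into an acetoxy group. The difference between the two cores is not broken down here.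

In this assay compound 1 gives > 100 ug/mL, which is a limit of the assay rather than a number. Compound 2 likewise gives > 100 ug/mL, again a limit. Compound 3 also gives > 100 ug/mL, a limit once more.

The change from compound 2 to compound 1 is acetyl in place of hydrogen on an oxygen on a saturated carbon. Its measured size is a step that the two limits leave unreadable from compound 2 to compound 1, because of the limit of > 100 ug/mL in this assay, at which 3 of the 3 values shown sit. The change made from compound 3 to compound 4 is acetyl in place of hydrogen on an oxygen on a saturated carbon, the same change on the other core.

The step from compound 3 to compound 4 is expected to be a step that the limit leaves unreadable from compound 3 to compound 4. That expectation rests on compound 3 giving only the limit > 100 ug/mL, and on the same change, on the first core, leaving both partners at the limit as well. Compound 4 is therefore estimated to land near 150 ug/mL in this assay, somewhere between 60 ug/mL and 400 ug/mL, most likely again as a limit.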

Compound 4, half-maximal inhibitory concentration: > 100 ug/mL
Compound 4 was reported as a limit; the forecaster's own chance of this, stated with the estimate: 75%; the middle value is on the limit's open side.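

No size can be read for the change from compound 3 to compound 4, the hydroxy to acetoxy swap, because both compounds stand at the same limit and neither gives a number: the limit of > 100 ug/mL in this assay, at which 4 of the 4 values shown sit.

The compounds shown leave open whether hydroxy to acetoxy makes any difference on either core, and how strong an inhibitor any of these four compounds is.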